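Thioether replacement on a shared imide core

This account rests on a few compounds, and the source may have more. Where it says the series, first, only, none or still open, it means among the compounds named here.

Measured compounds:
compound 1 `COC(=O)[C@@H]1N=C(SCc2ccccc2)[C@H]2C(=O)N(c3ccccc3)C(=O)[C@H]21` — 98%
compound 2 `CCCCSC1=N[C@H](C(=O)OC)[C@@H]2C(=O)N(c3ccccc3)C(=O)[C@H]12` — 89%

In a functional assay for inhibition, tested at 100 uM (on this read-out lower numbers stand for less inhibition and higher numbers for more inhibition at the one concentration tested (going by the name of the read-out)), compound 1 gives 98%. This is the higher of the two numbers shown, but compound 2, which gives 89%, lies within the scatter of it, so the two values show no order between them; both stand near the top of the percentage read-out.

The account then moves to compound 3 `CCCSC1=N[C@@H](C(=O)OC)[C@@H]2C(=O)N(c3ccccc3)C(=O)[C@H]12`, which has not yet been measured. Compared with compound 1 the change is ethyl in place of phenyl on a saturated chain carbon bound to a sulfur. Going by the values given here, no step between measured compounds covers this change, so the expectation rests on the two values alone. With compound 1 already at 98% there is little room for an upward step, and compound 2, carrying a different group on the same sulfur, gives 89%. Compound 3 is therefore expected to give 90%, with a range from 78% to 99%. The step expected is a number 8 percentage points lower from compound 1 to compound 3 (within the scatter), a small downward move that should stay within the scatter.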

Compound 3, a percentage reported as inhibition, at one concentration (the size of the read-out at that concentration, not a potency): 86%
The estimate for compound 3 lay 4 percentage points above the measured number; the range from low to high includes it.
By their numbers in this assay, from the lowest: compounds 3, 2 and 1 (each within the scatter of the next, the first and the last beyond it).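

In this assay, going by these compounds alone, the change from benzylsulfanyl to propylsulfanyl gives the first step that can be read at this position, a number 12 percentage points lower from compound 1 to compound 3 (beyond the scatter), a modest move with ethyl in place of phenyl on a saturated chain carbon bound to a sulfur. The phenyl ring is therefore not required for a high reading at the one concentration tested, as compound 3 still gives 86% with no ring on this chain, although the step shows that the replacement does not leave the number fully intact. Nothing measured here accounts for the step, so it stands as an observation without an explanation.

What the compounds leave open is whether this step follows the loss of the ring or the shorter chain, as one pair of compounds cannot separate the two. Also open, on these data alone, is how this assay would read with an amine, a carboxylic acid or a longer chain in place of phenyl on the same saturated chain carbon bound to a sulfur.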